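A few compounds are considered here, and "the series" means these few. Any claim that something is new, unique, unknown or untested is made for them only; others in the source may bear on it.

Three compounds share one core and differ only in the group on an amine nitrogen in a ring. Compound 1 `CCOC(=O)N1CCN(CC(O)Cn2c([N+](=O)[O-])cnc2C)CC1` carries an ethoxycarbonyl there, compound 2 `Cc1ncc([N+](=O)[O-])n1CC(O)CN1CCN(c2ccccc2)CC1` a phenyl, and compound 3 `Cc1ncc([N+](=O)[O-])n1CC(O)CN1CCN(c2ccccn2)CC1` a pyridin-2-yl. In a toxicity assay on HeLa cells (Homo sapiens) for cytotoxicity, read by MTT assay, with a stated time of 24 h (on this read-out higher numbers stand for weaker inhibition and lower numbers for stronger inhibition), compound 1 gives 3670000 nM. Compound 2 reaches only the limit of the assay, > 5000000 nM, and so yields no number. Compound 3 gives 1830000 nM; against compound 1 the step of a 2.0-fold lower number from compound 1 to compound 3 (0.30 log units; within the scatter), and against compound 2 the step of an at least 2.7-fold lower number from compound 2 to compound 3 (0.43 log units; beyond the scatter). The step of an at least 1.3-fold higher number from compound 1 to compound 2 (0.13 log units; that floor lies within the scatter) completes the picture: the only clear movement among these three came when pyridin-2-yl replaced phenyl.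

Compound 4 `Cc1ncc([N+](=O)[O-])n1CC(O)CN1CCN(c2ncccn2)CC1` has not yet been measured. It differs from compound 3 in one place: pyrimidin-2-yl in place of pyridin-2-yl on an amine nitrogen in a ring. The step that bears on this change is an at least 2.7-fold lower number from compound 2 to compound 3 (0.43 log units; beyond the scatter), where a first ring nitrogen entered the six-membered aromatic ring; here a second one enters. Since that earlier step rested on a compound sitting at the limit of > 5000000 nM in this assay, at which 1 of the 3 values shown sits, its true size is uncertain, and no step beyond the scatter is expected here. Compound 4 is expected to give about 1800000 nM, between 700000 nM and 4500000 nM. The expected step of a 1.0-fold lower number from compound 3 to compound 4 (0.01 log units; within the scatter) stays within the scatter.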

Compound 4, half-maximal inhibitory concentration: 3930000 nM
Compound 4: middle estimate off by 2.2-fold (0.34 log units), on the low side; measured number inside the range.
By their numbers in this assay, from the lowest: compounds 3, 1 and 4 (each within the scatter of the next, the first and the last beyond it). At a limit, above all of these: compound 2.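

In this assay, a second nitrogen in the six-membered aromatic ring does not continue what the first one did at this position: the first came with an at least 2.7-fold lower number from compound 2 to compound 3 (0.43 log units; beyond the scatter), whereas the second brings a 2.1-fold higher number from compound 3 to compound 4 (0.33 log units; beyond the scatter). Across the compounds shown, then, adding ring nitrogens on this amine nitrogen does not move the number in one steady direction, and compound 4 is the compound that goes against any such trend. The pyrimidin-2-yl and ethoxycarbonyl groups cannot be told apart at this position, with a 1.1-fold higher number from compound 1 to compound 4 (0.03 log units; within the scatter), while the remaining step, an at least 1.2-fold lower number from compound 2 to compound 4 (0.10 log units; that floor lies within the scatter), gives only a floor and cannot be read as a true size: the limit of > 5000000 nM in this assay, at which 1 of the 4 values shown sits.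

What lies behind the difference between pyridin-2-yl and pyrimidin-2-yl cannot be told from these numbers alone. On these data alone, it also remains open how the number would respond to other groups on this amine nitrogen, such as pyrazin-2-yl, with its two ring nitrogens placed differently, or a small alkyl group such as methyl, or an acyl group such as acetyl.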